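From 2-nitrophenyl to 3-aminophenyl on the shared core

The source may hold more compounds than are shown below. What is called first, only, known or untested is meant among the compounds shown, and "the series" means these compounds.

In a functional assay on MCF7 cells (Homo sapiens) for cytotoxicity, read by MTT assay, with a stated time of 96 h (a higher number here means a weaker inhibitor, a lower number a stronger inhibitor), compound 1 `COc1cc(C(=O)c2cn(-c3ccccc3)cc2-c2ccccc2[N+](=O)[O-])cc(OC)c1OC` gives 49 nM, compound 2 `COc1cc(C(=O)c2cn(-c3cccc(C)c3)cc2-c2cccc(N)c2)cc(OC)c1OC` gives 130 nM and compound 3 `COc1cc(C(=O)c2cn(-c3cccc(N)c3)cc2-c2ccccc2[N+](=O)[O-])cc(OC)c1OC` gives 14 nM. Compound 3 thus has the lowest number of the three, and its gaps to both others lie beyond the scatter. Compound 4 `COc1cc(C(=O)c2cn(-c3cccc(N)c3)cc2-c2cccc(N)c2)cc(OC)c1OC` carries 3-aminophenyl in place of 2-nitrophenyl on an aromatic carbon of the five-membered aromatic ring with 1 nitrogen: 3-aminophenyl in place of 2-nitrophenyl on an aromatic carbon.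

Going by the values given here, no measured step covers this exchange directly. Among the compounds with values here, the one measured step, a 3.5-fold lower number from compound 1 to compound 3 (0.54 log units; beyond the scatter), is a modest change beyond the scatter, with amino in place of hydrogen on an aromatic carbon, and compound 4 keeps that amino group. Compound 2 already carries the entering 3-aminophenyl group and gives 130 nM, but it has methyl where compound 4 has amino. Compound 4 is therefore expected to fall between compound 3 and compound 2, which means a modest rise in the number. The expected change is a 2.9-fold higher number from compound 3 to compound 4 (0.46 log units; beyond the scatter). The estimated value for compound 4 is 40 nM, with an expected range from 12 nM to 130 nM.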

Compound 4, half-maximal inhibitory concentration: 60 nM
Estimate against measurement, compound 4: 1.5-fold (0.18 log units) below, within the range that was stated.
By their numbers in this assay, from the lowest: compound 3; then compounds 1 and 4 (each within the scatter of the next); then compound 2.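

Going by these compounds alone, compound 4 gives the first direct reading of this exchange on an aromatic carbon of the five-membered ring: in this assay there is a 4.3-fold higher number from compound 3 to compound 4 (0.63 log units; beyond the scatter) with 3-aminophenyl in place of 2-nitrophenyl, so the entering group costs a modest amount here. With 3-aminophenyl in place, amino instead of methyl still lowers the number, with a 2.2-fold lower number from compound 2 to compound 4 (0.34 log units; beyond the scatter) as the result, which runs in the same direction as the earlier 3.5-fold lower number from compound 1 to compound 3 (0.54 log units; beyond the scatter) when amino replaced hydrogen. No measurement at hand accounts for either new step.

The compounds shown leave open whether the rise follows the change of group or its place on the phenyl ring, which 2-aminophenyl or 3-nitrophenyl on this carbon would separate. Also open, as far as these compounds go, is how a methoxy group or a carboxylic acid on this phenyl ring would read.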